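The source may report more compounds than this note shows. Statements on the series, on what has been measured and on what is new or still open speak of the compounds shown alone.

Working notes on the series.

Two compounds carry numbers in an in vitro functional assay on HEK293 cells for antagonist activity at melanin-concentrating hormone receptor 1 (Homo sapiens), read by GTPgammaS binding, with a stated time of 45 min; on this read-out lower numbers stand for stronger inhibition and higher numbers for weaker inhibition. Compound 1 `Cc1ccc(CN2CCC(CCN(Cc3ccc(-c4ccccc4)cc3)C(=O)NC(C)C)CC2)cc1` gives 220 nM in this assay. Compound 2 `COc1ccc(-c2ccc(CN(CCC3CCN(Cc4ccc(C)cc4)CC3)C(=O)NC(C)(C)COC(C)=O)cc2)cc1` gives 647 nM in this assay, the higher of the two numbers; compound 2 and compound 1 differ in more than one place, so the gap between them is not tied to a single change and is only recorded as what the two values show.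

Compound 3 `CC(=O)OCC(C)(C)NC(=O)N(CCC1CCN(Cc2ccc(C)cc2)CC1)Cc1ccc(-c2ccccc2)cc1` is not yet measured. It differs from compound 2 by hydrogen in place of methoxy on an aromatic carbon, placed on an aromatic carbon of a six-membered aromatic ring of carbon only, para to a large group; one bond further out, 4-methoxyphenyl becomes phenyl. Among the compounds with values here, no measured pair isolates this change, so its size is open. The expectation is a small step toward a lower number, about a 1.6-fold lower number from compound 2 to compound 3 (0.21 log units; within the scatter), possibly within the scatter. Compound 3 is therefore estimated at 400 nM, with a range from 150 nM to 1100 nM.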

Compound 3, antagonist equilibrium constant: 366 nM
For compound 3 the middle estimate is 1.1-fold (0.04 log units) above the measured one; the range from low to high includes it.
By their numbers in this assay, from the lowest: compounds 1, 3 and 2 (each within the scatter of the next, the first and the last beyond it).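

Hydrogen in place of methoxy, on an aromatic carbon para to a large group, is now isolated by a single pair in this assay: the step (a 1.8-fold lower number from compound 2 to compound 3 (0.25 log units; within the scatter)) lies within the scatter, so 4-methoxyphenyl and phenyl are not told apart at this place. Acetoxymethyl in place of hydrogen on the saturated chain carbon bound to an amide-type nitrogen and two saturated chain carbons is isolated by a second pair, and this step (a 1.7-fold higher number from compound 1 to compound 3 (0.22 log units; within the scatter)) also lies within the scatter. No measurement on hand bears on the cause of either reading.

Going by these compounds, whether an amine or a hydroxyl on that aromatic carbon would give a step beyond the scatter stays open. The same holds for a carboxylic acid or a longer chain in place of acetoxymethyl.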